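The source may hold more compounds than are shown below. What is called first, only, known or untested is meant among the compounds shown, and "the series" means these compounds.

In a functional assay on HCT-116 cells (Homo sapiens) for cytotoxicity, read by MTT assay (on this read-out higher numbers stand for weaker inhibition and lower numbers for stronger inhibition), compound 1 `COc1ccc(-c2ccnc(NCc3ccc(C(=O)Nc4ccccc4N)cc3)n2)cc1OC` gives 100 nM and compound 2 `Nc1nc(NCc2ccc(C(=O)Nc3ccccc3N)cc2)nc(NC2CCCC2)n1` gives 700 nM. Compound 2 thus has the higher of the two numbers, and the gap lies beyond the scatter. Compound 3 `Nc1nc(NCc2ccc(C(=O)Nc3ccccc3N)cc2)nc(N2Cc3ccccc3C2)n1` keeps the core of compound 2 and differs in one group on an aromatic carbon: a group of 9 heavy atoms (8 carbon, 1 nitrogen; one five-membered non-aromatic ring with 1 hetero atom, one six-membered aromatic ring of carbon only) in place of a group of 6 heavy atoms (5 carbon, 1 nitrogen; one five-membered non-aromatic ring of carbon only), on an aromatic carbon. Among the compounds with values here, no measured pair shows a change of this kind, so the expectation is only tentative. The estimated step in this assay is toward a lower number but not beyond the scatter: a 1.4-fold lower number from compound 2 to compound 3 (0.15 log units; within the scatter). For compound 3 the expected value is 500 nM, with an estimated range of 150 nM to 1600 nM.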

Compound 3, half-maximal inhibitory concentration: 500 nM
Compound 3: the middle estimate sits on the measured number at the digits printed; low and high end bracket the measured number.
By their numbers in this assay, from the lowest: compound 1; then compounds 3 and 2 (each within the scatter of the next).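

At this position, on an aromatic carbon between two ring nitrogen atoms, putting the group of 9 heavy atoms with its six-membered aromatic ring and no hydrogen-bond donor in place of cyclopentylamino gives a 1.4-fold lower number from compound 2 to compound 3 (0.15 log units; within the scatter) in this assay. The added ring and the lost donor therefore leave the number within the scatter, which compound 1 and compound 2 alone could not show. Nothing at hand explains this result. The compounds shown leave open how a plain amine, a morpholine ring or a longer alkyl chain at this position would read in this assay.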